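A few compounds are considered here, and "the series" means these few. Any claim that something is new, unique, unknown or untested is made for them only; others in the source may bear on it.

In a functional assay on KB cells (Homo sapiens) for antiproliferative activity, with a stated time of 48 h (a lower number here means a stronger inhibitor, a higher number a weaker inhibitor), compound 1 (`C=CCN1c2c(N)nc(N)nc2CCC1CN(C)c1ccc(C(=O)N[C@@H](CCC(=O)O)C(=O)O)cc1`) gives > 100000 nM, which is a limit of the assay. Compound 2 (`C=CCN1c2c(N)nc(N)nc2CCC1CNc1ccc(C(=O)N[C@@H](CCC(=O)O)C(=O)O)cc1`) gives > 100000 nM, which is also a limit, so it has no numerical standing. For the measured compounds named here, the one measured step, a step that the two limits leave unreadable from compound 1 to compound 2, offers no size to carry forward. Compound 3 (`C=CCN(CC1CCc2nc(N)nc(N)c2N1CC=C)c1ccc(C(=O)N[C@@H](CCC(=O)O)C(=O)O)cc1`) differs from compound 2 by allyl in place of hydrogen on a nitrogen on an aromatic ring. Because the limit of > 100000 nM in this assay, at which 2 of the 2 values shown sit, describes every reading so far, no gain in potency is expected. The expected change is a number no higher from compound 2 to compound 3 (the limit leaves the size open). Compound 3 is estimated at 100000 nM, within an expected range of 30000 nM to 200000 nM.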

Compound 3, half-maximal inhibitory concentration: 6720 nM
Beside the measured number, compound 3's estimate is 15-fold (1.17 log units) above it; the measured number lies below the stated range.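

In this assay, for the compounds shown here, allyl in place of hydrogen on a nitrogen on an aromatic ring brings the only reading that is not a limit, with an at least 14-fold lower number from compound 2 to compound 3 (1.17 log units; beyond the scatter). Methyl at this nitrogen gave no such reading, whereas extending that methyl to allyl gives an at least 14-fold lower number from compound 1 to compound 3 (1.17 log units; beyond the scatter). Both sizes are only bounds, since each starting compound sits at a limit: the limit of > 100000 nM in this assay, at which 2 of the 3 values shown sit.

Going by these compounds, whether a propyl chain, which lacks the double bond, or a longer chain such as butyl at this nitrogen would give a comparable number remains open.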